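The compounds below may be only part of what the source reports. "The series", "measured", "known", "first", "only" and "open" are said of these compounds alone.

Working notes on the series, read in a functional assay on B16 cells (Mus musculus) for inhibition; on this read-out lower numbers stand for stronger inhibition and higher numbers for weaker inhibition. Compound 1 `COc1cc2oc(=O)cc(COC(=O)/C=C/c3ccccc3)c2cc1OC` gives > 10 ug/mL, which is a limit of the assay and not a number. For the measured compounds named here, compound 2 `COc1ccc(/C=C/C(=O)OCc2cc(=O)oc3cc(OC)c(OC)cc23)cc1` gives 0.96 ug/mL, the only true number so far. Going by the values given here, the single measured step is an at least 10-fold lower number from compound 1 to compound 2 (1.01 log units; beyond the scatter), with methoxy in place of hydrogen on an aromatic carbon. Its size is a lower bound, since it starts from the limit of > 10 ug/mL in this assay, at which 1 of the 2 values shown sits.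

Compound 3 `COc1ccc(/C=C/C(=O)OCc2cc(=O)oc3cc(OC)c(OC)cc23)cc1O` changes the same aryl group further: hydroxy in place of hydrogen on an aromatic carbon, which reads as 4-methoxyphenyl to 3-hydroxy-4-methoxyphenyl. The measured step bears on this only loosely. Among the compounds with values here, it shows that a substituent on this ring can move the read-out strongly, as in an at least 10-fold lower number from compound 1 to compound 2 (1.01 log units; beyond the scatter), but it involves a different group at a different place, and no hydroxy step has been measured. No clear direction is therefore expected, and the range is kept wide on both sides. The expected step is a 1.3-fold higher number from compound 2 to compound 3 (0.10 log units; within the scatter). Compound 3 is estimated at 1.2 ug/mL, with an expected range of 0.3 ug/mL to 6 ug/mL.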

Compound 3, half-maximal inhibitory concentration: 3 ug/mL
Beside the measured number, compound 3's estimate is 2.5-fold (0.40 log units) below it, and the stated range covers the measured number.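

In this assay, the place on the aryl ring ortho to a methoxy group now has a reading of its own: the change from 4-methoxyphenyl to 3-hydroxy-4-methoxyphenyl gives a 3.1-fold higher number from compound 2 to compound 3 (0.49 log units; beyond the scatter), so adding hydroxy here moves the read-out towards weaker inhibition, which the methoxy step alone could not show. The substituted ring still keeps an advantage over the unsubstituted phenyl, with an at least 3.3-fold lower number from compound 1 to compound 3 (0.52 log units; beyond the scatter), so the hydroxy group gives back only part of what separates compound 2 from compound 1. Compound 1 gives > 10 ug/mL, which is a limit of the assay and not a number, so this last step is a lower bound: the limit of > 10 ug/mL in this assay, at which 1 of the 3 values shown sits.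

The compounds shown leave open whether the loss belongs to the hydroxy group as such or to any group at this place, a question that a second methoxy group or a fluorine atom in the same place would bear on. Also open, as far as these compounds go, is how far the methoxy group of compound 2 can be replaced, for instance by a chlorine atom or a dimethylamino group.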